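The source may report more compounds than this note shows. Statements on the series, on what has been measured and on what is new or still open speak of the compounds shown alone.

Measured in an ADME assay on L02 cells (Homo sapiens) for antiproliferative activity, read by MTT assay, with a stated time of 48 h; a lower number here means a stronger inhibitor, a higher number a weaker inhibitor:
- compound 1 `C=CCN(C)C(=O)c1ccc(C(CC)(CC)c2ccc(OCCC(O)(CC)CC)c(C)c2)n1CC`: 1190 nM
- compound 2 `CCn1c(C(=O)N(C)CCO)ccc1C(CC)(CC)c1ccc(OCCC(O)(CC)CC)c(C)c1`: 2050 nM

Compound 2, at 2050 nM, lies within the scatter of compound 1, so the two cannot be ranked. The next case is compound 3 `CCn1c(C(=O)NC(C)CO)ccc1C(CC)(CC)c1ccc(OCCC(O)(CC)CC)c(C)c1`, an isomer of compound 2: (1-(hydroxymethyl)ethyl)amino in place of (2-hydroxyethyl)(methyl)amino on a carbonyl carbon. The exchange is (1-(hydroxymethyl)ethyl)amino in place of (2-hydroxyethyl)(methyl)amino on a carbonyl carbon.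

Within the data shown here, no measured compound carries the entering group. Among the measured compounds shown here, the one measured step, a 1.7-fold higher number from compound 1 to compound 2 (0.24 log units; within the scatter), is a different exchange, hydroxymethyl in place of vinyl, and gives only indirect guidance. With that single small step as the guide, no change beyond the scatter is expected in this assay, and neither direction is favoured. The expected step is a 1.1-fold lower number from compound 2 to compound 3 (0.06 log units; within the scatter). Compound 3 is estimated at 1800 nM, with an expected range of 650 nM to 5500 nM.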

Compound 3, half-maximal inhibitory concentration: 4840 nM
For compound 3 the middle estimate is 2.7-fold (0.43 log units) below the measured one, and the stated range covers the measured number.
By their numbers in this assay, from the lowest: compounds 1 and 2 (each within the scatter of the next); then compound 3.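

At this position, on a carbonyl carbon, an exchange that keeps the same atoms but joins them differently still registers in this assay: (1-(hydroxymethyl)ethyl)amino in place of (2-hydroxyethyl)(methyl)amino gives a 2.4-fold higher number from compound 2 to compound 3 (0.37 log units; beyond the scatter). Compared with allyl(methyl)amino, the same entering group gives a 4.1-fold higher number from compound 1 to compound 3 (0.61 log units; beyond the scatter), so the series now shows steps beyond the scatter at this carbonyl carbon, where compound 1 and compound 2 could not be ranked. Nothing available bears on why this exchange shifts the number.

The exchange from compound 2 to compound 3 alters the nitrogen substitution and the chain together, so the two contributions remain unseparated. A simple (2-hydroxyethyl)amino group would address that, while a carboxylic acid or a longer hydroxyalkyl chain on the amide nitrogen remains an open case.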